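This account rests on a few compounds, and the source may have more. Where it says the series, first, only, none or still open, it means among the compounds named here.

Of the compounds shown here, three sharing one core have been measured in an assay on CHO-K1 cells for antagonist activity at adenosine receptor A1 (Homo sapiens), read by a beta-galactosidase reporter, with stated times of 15 min and 6 h; a lower number here means a stronger inhibitor, a higher number a weaker inhibitor. Compound 1 `CN(C)Cc1cc2c(N)nc(-c3ccco3)nc2s1` gives 3550 nM, compound 2 `Nc1nc(-c2ccco2)nc2sc(CNC3CCCCC3)cc12` gives 2480 nM, and compound 3 `Nc1nc(-c2ccco2)nc2sc(CN3CCCC3)cc12` gives 6430 nM. Compound 3 thus carries the highest number of the three, separated from compound 1 by a step within the scatter and from compound 2 by a step beyond it. Compound 4 `Nc1nc(-c2ccco2)nc2sc(CN3CCC(F)(F)CC3)cc12` differs from compound 3 in one place: 4,4-difluoropiperidin-1-yl in place of pyrrolidin-1-yl on a saturated chain carbon bound to an aromatic carbon. Going by the values given here, two measured steps touch the same position. Replacing dimethylamino with pyrrolidin-1-yl gave a 1.8-fold higher number from compound 1 to compound 3 (0.26 log units; within the scatter), and replacing cyclohexylamino with pyrrolidin-1-yl gave a 2.6-fold higher number from compound 2 to compound 3 (0.41 log units; beyond the scatter). Both changes at this saturated chain carbon moved the number only modestly, so a further exchange of one cyclic tertiary amine for another is expected to give a step in this assay no larger than those, with no clear direction beyond the scatter. Compound 4 is therefore expected to show 5000 nM, with a range from 2000 nM to 12000 nM, which would mean a 1.3-fold lower number from compound 3 to compound 4 (0.11 log units; within the scatter).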

Compound 4, inhibition constant: 2230 nM
Compound 4: the middle estimate sits 2.2-fold (0.35 log units) above what was measured, and the stated range covers the measured number.
By their numbers in this assay, from the lowest: compounds 4, 2, 1 and 3 (each within the scatter of the next, the first and the last beyond it).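

In this assay, 4,4-difluoropiperidin-1-yl in place of pyrrolidin-1-yl gives a 2.9-fold lower number from compound 3 to compound 4 (0.46 log units; beyond the scatter), so one cyclic tertiary amine exchanged for another at this saturated chain carbon can move the number beyond the scatter. The new group does not separate from the two open-chain or secondary amines, with a 1.1-fold lower number from compound 2 to compound 4 (0.05 log units; within the scatter) and a 1.6-fold lower number from compound 1 to compound 4 (0.20 log units; within the scatter); the steps beyond the scatter at this position both involve pyrrolidin-1-yl, though the step from compound 1 to compound 3 goes against this by staying within the scatter. Nothing available accounts for the step from compound 3 to compound 4.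

The compounds shown leave open whether the ring of six or the two fluorine atoms matters here, which unsubstituted piperidin-1-yl would help to separate. From the compounds shown here alone, how morpholin-4-yl would read at this place also stays open.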